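The source may hold more compounds than are shown below. What is called first, only, known or untested is meant among the compounds shown, and "the series" means these compounds.

Compound 1 `CN(CC1=CC[C@H]2C[C@@H]1C2(C)C)Cc1ccccc1` is the simplest member of this small set. In an assay on HEK293 cells for displacement of a labelled ligand from C-X-C chemokine receptor type 3 (Homo sapiens) (on this read-out higher numbers stand for weaker inhibition and lower numbers for stronger inhibition), compound 1 gives 15800 nM. Compound 2 `CC(=O)c1cccc(-c2ccc(CN(C)CC3=CC[C@H]4C[C@@H]3C4(C)C)cc2)c1` carries a 3-acetylphenyl group on an aromatic carbon of the shared core. In this assay compound 2 gives only a limit, > 316 nM. Among the measured compounds shown here, that leaves the step that the limit leaves unreadable from compound 1 to compound 2 unreadable in size; the one piece of evidence about it is the limit of > 316 nM in this assay, at which 1 of the 2 values shown sits. Compound 3 `CN(CC1=CC[C@H]2C[C@@H]1C2(C)C)Cc1ccc(-c2cc(Cl)cc(Cl)c2)cc1` is the compound whose value is still to be measured. The change is 3,5-dichlorophenyl in place of 3-acetylphenyl on an aromatic carbon. No measured step covers this exchange, and the only measured step is itself unreadable, so no direction can be taken from the numbers shown. For compound 3 the expected step that the limit leaves unreadable from compound 2 to compound 3 is therefore set near nothing beyond the scatter, with wide uncertainty. Compound 3 is estimated at 1000 nM, with a range from 200 nM to 10000 nM.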

Compound 3, inhibition constant: > 316 nM
Compound 3 was reported as a limit; the forecaster's own chance of this, stated with the estimate: 60%; the middle value is on the limit's open side.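

In this assay compound 3 gives only a limit, > 316 nM, so the steps to compound 3 from compound 1 and compound 2 cannot be read in size: the limit of > 316 nM in this assay, at which 2 of the 3 values shown sit. The compounds shown leave open whether 3,5-dichlorophenyl and 3-acetylphenyl differ at all in this binding read-out.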